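From Chloro to Bromo in a Carboxy-Bearing Series

A few compounds are considered here, and "the series" means these few. Any claim that something is new, unique, unknown or untested is made for them only; others in the source may bear on it.

compound 1 `CC#CCn1c(N2CCC[C@@H](N)C2)cc(=O)n(Cc2ccc(Cl)c(C(=O)O)c2)c1=O`: 70.7%
compound 2 `CC#CCn1c(N2CCC[C@@H](N)C2)cc(=O)n(Cc2ccc(F)c(C(=O)OC)c2)c1=O`: 56%
compound 3 `CC#CCn1c(N2CCC[C@@H](N)C2)cc(=O)n(Cc2ccc(Cl)c(C(=O)OC)c2)c1=O`: 34.4%

These three compounds were measured in an ADME assay on microsomes from liver (Mus musculus, strain ICR) for metabolic stability, read by LC-MS, using NADPH, with a stated time of 60 min, tested at 0.1 uM; a higher number here means that more of the compound is left, a lower number that less of the compound is left. Among them, compound 1 stands highest at 70.7%, ahead of compound 2 at 56% and compound 3 at 34.4%. The next compound in the account is compound 4 `CC#CCn1c(N2CCC[C@@H](N)C2)cc(=O)n(Cc2ccc(Br)c(C(=O)O)c2)c1=O`, which has not yet been measured. It keeps the core of compound 1 and its carboxy group, and carries bromo in place of chloro on an aromatic carbon.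

Among the compounds with values here, no measured compound yet carries bromo, so the expectation rests on indirect evidence. Within the data shown here, the closest precedent is a halogen exchange among the methyl esters, where chloro in place of fluoro on an aromatic carbon gave a number 21.6 percentage points lower from compound 2 to compound 3 (beyond the scatter). That step was modest, and it may not carry over to a free carboxy group. The exchange of the carboxy group for its methyl ester gave a number 36.3 percentage points lower from compound 1 to compound 3 (beyond the scatter), which was large, and this shows that the two series sit at different levels in this assay. A small downward step, smaller than the halogen step among the esters, is therefore expected. The estimated change is a number 9.7 percentage points lower from compound 1 to compound 4 (within the scatter). For compound 4 the expected value is 61%, with an estimated range from 44% to 75%.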

Compound 4, percent of the compound remaining: 58.2%
Compound 4: the middle estimate sits 2.8 percentage points above what was measured, and the stated range covers the measured number.
By their numbers in this assay, from the lowest: compound 3; then compounds 2 and 4 (each within the scatter of the next); then compound 1.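

In this assay the exchange of chloro for bromo on an aromatic carbon ortho to a carboxy group gave a number 12.5 percentage points lower from compound 1 to compound 4 (beyond the scatter) and so shows that this position still responds to a change of halogen when the free carboxy group is present. The earlier compounds had shown a halogen exchange here only among the methyl esters, and only from fluoro to chloro, through a number 21.6 percentage points lower from compound 2 to compound 3 (beyond the scatter) as the one step of that kind. Across these two pairs, which are the only halogen pairs shown, the heavier halogen goes with the lower number and neither pair goes against this, although the data give no reason for either step, and no measurement shown here explains the change from chloro to bromo.

The compounds shown leave open how fluoro, iodo or a plain hydrogen on this carbon would read with the free carboxy group, and so whether the two pairs reflect a trend running through the halogens. They also leave open whether bromo would give a similar step in the methyl ester, or with a primary amide in place of the carboxy group.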